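The source may report more compounds than this note shows. Statements on the series, on what has been measured and on what is new or still open speak of the compounds shown alone.

Three compounds share one core and differ only in the chlorophenyl group they carry. In a functional assay on SW-620 cells (Homo sapiens) for cytotoxicity, read by MTT assay, with a stated time of 72 h (a higher number here means a weaker inhibitor, a lower number a stronger inhibitor), compound 1 (`COc1cccc(/C=C2\CCC/C(=C\c3ccccc3Cl)C2=O)c1OC`) gives 10300 nM, compound 2 (`COc1cccc(/C=C2\CCC/C(=C\c3cccc(Cl)c3)C2=O)c1OC`) gives 9100 nM and compound 3 (`COc1cccc(/C=C2\CCC/C(=C\c3ccc(Cl)cc3)C2=O)c1OC`) gives 11100 nM. Compound 3 therefore stands level with the other two, and no order can be read among them. The measured steps are a 1.1-fold lower number from compound 1 to compound 2 (0.05 log units; within the scatter), a 1.1-fold higher number from compound 1 to compound 3 (0.03 log units; within the scatter) and a 1.2-fold higher number from compound 2 to compound 3 (0.09 log units; within the scatter).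

The next compound, compound 4 (`COc1cccc(/C=C2\CCC/C(=C\c3ccccc3Br)C2=O)c1OC`), carries 2-bromophenyl in place of 4-chlorophenyl on a double-bonded chain carbon bound to a double-bonded ring carbon. Two of the measured steps bear on this change. The step of a 1.1-fold higher number from compound 1 to compound 3 (0.03 log units; within the scatter) links the 2-chlorophenyl and 4-chlorophenyl groups, and a 1.2-fold higher number from compound 2 to compound 3 (0.09 log units; within the scatter) shows the same flat picture for the remaining chlorophenyl group. Among the measured compounds shown here, no measured compound carries bromine, so that part of the change remains untested. On the chlorophenyl evidence alone, no shift beyond the scatter is expected in this assay. The expected change is small, a 1.1-fold lower number from compound 3 to compound 4 (0.05 log units; within the scatter). Compound 4 is estimated at 10000 nM, with an expected range of 6000 nM to 17000 nM.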

Compound 4, half-maximal inhibitory concentration: 12100 nM
The estimate for compound 4 lay 1.2-fold (0.08 log units) below the measured number; low and high end bracket the measured number.
By their numbers in this assay, from the lowest: compounds 2, 1, 3 and 4 (each within the scatter of the next).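

The first bromine in the set leaves the picture in this assay flat: bromo in place of chloro on an aromatic carbon gives (a 1.2-fold higher number from compound 1 to compound 4 (0.07 log units; within the scatter)), so this single direct exchange of halogen brings no shift beyond the scatter. The two steps that change the halogen and its ring location together, (a 1.1-fold higher number from compound 3 to compound 4 (0.04 log units; within the scatter)) and (a 1.3-fold higher number from compound 2 to compound 4 (0.12 log units; within the scatter)), also stay within the scatter, and 2-bromophenyl therefore joins the three chlorophenyl groups as a level set of four on a double-bonded chain carbon bound to a double-bonded ring carbon. No measurement of any other property is available to explain why these steps stay so small.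

As far as these compounds go, every group compared here is a phenyl ring bearing a single halogen, so it remains open whether an amine or a carboxylic acid on that ring would move the number beyond the scatter. From the compounds shown here alone, it also remains open whether this flat response would hold in any other cell line, or with a change elsewhere in the shared core.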